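The compounds below may be only part of what the source reports. "The series", "measured", "known", "first", "only" and "open" are said of these compounds alone.

In a functional assay for inhibition, with Homo sapiens as the target (a lower number here means a stronger inhibitor, a higher number a weaker inhibitor), three compounds with a shared core differ in the group on a saturated chain carbon bound to an oxygen on an aromatic ring. Compound 1 `CC(C)(C)Sc1c(CC(C)(C)C(=O)O)n(Cc2ccc(Cl)cc2)c2ccc(OCc3ccc4cc(F)ccc4n3)cc12` gives 2 nM, compound 2 `CC(C)(C)Sc1c(CC(C)(C)C(=O)O)n(Cc2ccc(Cl)cc2)c2ccc(OCc3ccc4cccnc4n3)cc12` gives 6 nM, and compound 3 `CC(C)(C)Sc1c(CC(C)(C)C(=O)O)n(Cc2ccc(Cl)cc2)c2ccc(OCc3cnccn3)cc12` gives 4 nM. Compound 3 cannot be ranked against the other two. The steps are a 2.0-fold higher number from compound 1 to compound 3 (0.30 log units; within the scatter) and a 1.5-fold lower number from compound 2 to compound 3 (0.18 log units; within the scatter), both within the scatter. Only a 3.0-fold higher number from compound 1 to compound 2 (0.48 log units; beyond the scatter) lies beyond it, and that step is modest.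

Compound 4 `CC(C)c1csc(COc2ccc3c(c2)c(SC(C)(C)C)c(CC(C)(C)C(=O)O)n3Cc2ccc(Cl)cc2)n1` differs from compound 3 by 4-isopropyl-1,3-thiazol-2-yl in place of pyrazin-2-yl on a saturated chain carbon bound to an oxygen on an aromatic ring. Among the measured compounds shown here, no measured compound carries 4-isopropyl-1,3-thiazol-2-yl, so the three measured steps bear on this change only indirectly. They show how far this assay has moved across exchanges of other aromatic groups at this place. No step beyond the scatter is therefore expected, and the data favour no direction. The expected step is no change at the digits printed from compound 3 to compound 4 (within the scatter). Compound 4 is estimated at 4 nM, with an expected range of 1.5 nM to 12 nM.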

Compound 4, half-maximal inhibitory concentration: 3 nM
Compound 4: middle estimate off by 1.3-fold (0.12 log units), on the high side; the range from low to high includes it.
By their numbers in this assay, from the lowest: compounds 1, 4, 3 and 2 (each within the scatter of the next, the first and the last beyond it).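

In this assay, among the compounds shown here, the earlier compounds carried only six-membered aromatic rings at this place, while 4-isopropyl-1,3-thiazol-2-yl brings a five-membered aromatic ring with a sulfur in it, and all three new steps stay within the scatter: a 1.3-fold lower number from compound 3 to compound 4 (0.12 log units; within the scatter), a 2.0-fold lower number from compound 2 to compound 4 (0.30 log units; within the scatter) and a 1.5-fold higher number from compound 1 to compound 4 (0.18 log units; within the scatter). Among the compounds shown, then, neither the change of ring size nor the entry of sulfur on the saturated chain carbon produces a step beyond the scatter, and compound 4 cannot be ranked against any of the other three. Nothing available explains why the number holds across this change.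

Open, as far as these compounds go, is whether a non-aromatic group on this carbon, such as a piperidine, a primary amine or a carboxylic acid, would hold the number as these aromatic groups do. Also open, from the compounds shown here alone, is whether an unsubstituted 1,3-thiazol-2-yl would match 4-isopropyl-1,3-thiazol-2-yl.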